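The source may report more compounds than this note shows. Statements on the series, on what has been measured and on what is new or still open speak of the compounds shown alone.

Compound 1, with the structure `Cc1nc(Nc2ccc3sc(C(=O)Nc4c(C)cccc4Cl)cc3c2)cc(N2CCCCC2)n1`, sits at the weak end of the measurements made so far. In a functional assay on U-937 cells (Homo sapiens) for cytotoxicity, read by MTT assay and WST assay, with a stated time of 72 h (on this read-out higher numbers stand for weaker inhibition and lower numbers for stronger inhibition), compound 1 gives 20000 nM, the highest of the three numbers. Its two companions carry the same amide half on a different core: compound 2, `COc1cc2c(Nc3ccc4sc(C(=O)Nc5c(C)cccc5Cl)cc4c3)ncnc2cc1OCCCN1CCCCC1C`, gives 3450 nM in this assay, and compound 3, `COc1cc2c(Nc3ccc4sc(C(=O)Nc5c(C)cccc5Cl)cc4c3)ncnc2cc1OCCCN1CCCCC1`, gives 4340 nM.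

The change from compound 1 to compound 4, whose structure is `Cc1nc(Nc2ccc3sc(C(=O)Nc4c(C)cccc4Cl)cc3c2)cc(N2CCC(C)CC2)n1`, is methyl in place of hydrogen on a saturated ring carbon. For the measured compounds named here, the only measured step of the same kind, a methyl swapped for a hydrogen on a saturated ring carbon of a piperidine, is a 1.3-fold higher number from compound 2 to compound 3 (0.10 log units; within the scatter), and it moved the number hardly at all. That step sits on a different core and at a different ring carbon, so it is a loose guide, but it is the only one available.

Compound 4 is therefore expected to stay close to compound 1, with a step of no change at the digits printed from compound 1 to compound 4 (within the scatter) in this assay. The estimate for compound 4 is 20000 nM, within the range 8000 nM to 45000 nM.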

Compound 4, half-maximal inhibitory concentration: 20600 nM
The estimate for compound 4 lay 1.0-fold (0.01 log units) below the measured number, and the stated range covers the measured number.
By their numbers in this assay, from the lowest: compounds 2 and 3 (each within the scatter of the next); then compounds 1 and 4 (each within the scatter of the next).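

In this assay, replacing piperidin-1-yl with 4-methylpiperidin-1-yl gives a 1.0-fold higher number from compound 1 to compound 4 (0.01 log units; within the scatter), so a methyl on this carbon, three ring bonds from the ring nitrogen, leaves no readable mark on the number. For the compounds shown here, the earlier compounds showed a methyl swap on a saturated ring carbon on only one core, and the same change now reads alike on two: the same change on two cores in this assay, a 1.3-fold higher number (0.10 log units; within the scatter) from compound 2 to compound 3 and a 1.0-fold lower number (0.01 log units; within the scatter) from compound 4 to compound 1, 1.3-fold (0.11 log units) apart, within the scatter of two such steps The two steps place the methyl at different ring carbons, so this agreement concerns the methyl swap in general, and only the step on the core of compound 1 speaks for this particular carbon.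

On these data alone, whether a hydroxyl, an amine, a carboxylic acid or a longer chain such as propyl at this carbon would move the number remains open. Also open, as far as these compounds go, is how a methyl would read on the other carbons of this ring.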